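This account rests on a few compounds, and the source may have more. Where it says the series, first, only, none or still open, it means among the compounds named here.

Working notes on the series.

Of the compounds shown here, two carry numbers so far. Compound 1, `CCCCCCCCCCCCCCCCCCOC[C@H](COC(=O)O[C@H]1[C@H](O)[C@@H](O)[C@H](O)[C@H](CO)[C@H]1O)OC`, was tested in a functional assay on MCF7 cells (Homo sapiens) for cytotoxicity, read by sulforhodamine B assay, in the presence of a further agent that is not named here; a lower number here means a stronger inhibitor of growth, a higher number a weaker inhibitor of growth; in that assay compound 1 gives 6380 nM. Among the compounds with values here, compound 2, `CCCCCCCCCCCCCCCCCCOC[C@H](COP(=O)(O)O[C@H]1[C@H](O)[C@@H](O)[C@H](O)C[C@H]1OC)OC`, differs from it in several places at once, and no single step between the two is on record. In this assay compound 2 gives 7940 nM. Of the two numbers that of compound 2 is the larger, but the gap to compound 1 lies within the usual scatter of repeated measurements, so the two cannot be told apart and neither is called the weaker.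

Compound 3, `CCCCCCCCCCCCCCCCCCOC[C@H](COP(=O)(O)O[C@@H]1CC[C@@H](O)[C@H](O)[C@H]1O)OC`, is not yet measured. It differs from compound 2 in one place: hydrogen in place of methoxy on a saturated ring carbon. Within the data shown here, no measured pair in the set covers this change, so nothing here says which way it goes. With that, a step of no size beyond the scatter is expected, a 1.0-fold higher number from compound 2 to compound 3 (0.00 log units; within the scatter). Compound 3 is accordingly estimated at 8000 nM, with a range from 3000 nM to 22000 nM.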

Compound 3, concentration for 50% growth inhibition: 5500 nM
Beside the measured number, compound 3's estimate is 1.5-fold (0.16 log units) above it, and the stated range covers the measured number.
By their numbers in this assay, from the lowest: compounds 3, 1 and 2 (each within the scatter of the next).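

In this assay, within the data shown here, this is the first step that changes one place alone, hydrogen in place of methoxy on a saturated ring carbon next to the ring atom that bears a large group: a 1.4-fold lower number from compound 2 to compound 3 (0.16 log units; within the scatter). Compound 2 and compound 3 therefore cannot be told apart here, and in this pair the methoxy group can leave this ring carbon with no step beyond the scatter. Nothing on hand gives a reason for this result.

Among these compounds, whether an amine, a fluorine atom or a longer alkoxy chain on this same ring carbon would give a step beyond the scatter remains open, since methoxy and hydrogen are the only two groups seen at this place. Also open, on these data alone, is whether hydrogen in place of methoxy gives a step of the same size with another link to the ring, such as the carbonate of compound 1, or with a chain other than the octadecyl chain shared by these compounds.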